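Ring Nitrogen Substitution Unlocks Antiproliferative Potency

The compounds below may be only part of what the source reports. "The series", "measured", "known", "first", "only" and "open" are said of these compounds alone.

compound 1: `Cc1ccc(C(=O)Nc2cccc(C(F)(F)F)c2)cc1-c1ccc2c(-c3cn[nH]c3)n[nH]c2c1` — > 1000 nM
compound 2: `CCn1cc(-c2n[nH]c3cc(-c4cc(C(=O)Nc5cccc(C(F)(F)F)c5)ccc4C)ccc23)cn1` — 19.8 nM
compound 3: `Cc1ccc(C(=O)Nc2cccc(C(F)(F)F)c2)cc1-c1ccc2c(-c3cnn(C4CCOC4)c3)n[nH]c2c1` — 69.7 nM

In a functional assay on NCI-H2286 cells (Homo sapiens) for antiproliferative activity, read by CCK-8 assay, with a stated time of 72 h (on this read-out higher numbers stand for weaker inhibition and lower numbers for stronger inhibition), compound 1 gives only a limit, > 1000 nM, and stands at the limit of > 1000 nM in this assay, at which 1 of the 3 values shown sits. Compound 4, `Cc1ccc(C(=O)Nc2cccc(C(F)(F)F)c2)cc1-c1ccc2c(-c3cnn(C4CCN(C)CC4)c3)n[nH]c2c1`, differs from compound 1 in one place: 1-methylpiperidin-4-yl in place of hydrogen on an aromatic nitrogen. Within the data shown here, two measured steps bear on this change, both placing a substituent on the same ring nitrogen of the shared core of compound 1. In this assay the first step is an at least 50-fold lower number from compound 1 to compound 2 (1.70 log units; beyond the scatter), and the second is an at least 14-fold lower number from compound 1 to compound 3 (1.15 log units; beyond the scatter). Between the two substituted compounds the difference is a 3.5-fold higher number from compound 2 to compound 3 (0.55 log units; beyond the scatter), so the saturated ring carrying a hetero atom sits somewhat above the small alkyl group. Because compound 1 only reaches the limit (the limit of > 1000 nM in this assay, at which 1 of the 3 values shown sits), the true size of these steps is not known, but both are large and point downward. A large downward step is therefore expected for compound 4 as well, an at least 16-fold lower number from compound 1 to compound 4 (1.22 log units; beyond the scatter), with a number closer to compound 3 than to compound 2 thought likely given the saturated ring entering. Compound 4 is estimated at 60 nM, within a range from 15 nM to 250 nM.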

Compound 4, half-maximal inhibitory concentration: 56.5 nM
The estimate for compound 4 lay 1.1-fold (0.03 log units) above the measured number, within the range that was stated.
By their numbers in this assay, from the lowest: compound 2; then compounds 4 and 3 (each within the scatter of the next). At a limit, above all of these: compound 1.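

In this assay, 1-methylpiperidin-4-yl on this aromatic nitrogen also brings a large change, an at least 17-fold lower number from compound 1 to compound 4 (1.24 log units; beyond the scatter), so a ring containing a nitrogen joins ethyl and oxolan-3-yl among the groups tolerated here, though this step is only a bound because compound 1 stands at a limit: the limit of > 1000 nM in this assay, at which 1 of the 4 values shown sits. Exchanging the oxolan-3-yl group for this six-membered ring makes no difference that can be read, a 1.2-fold lower number from compound 3 to compound 4 (0.09 log units; within the scatter), so the two saturated rings cannot be told apart in this assay. Ethyl keeps its lead over this ring too, a 2.9-fold higher number from compound 2 to compound 4 (0.46 log units; beyond the scatter), which matches the earlier gap, a 3.5-fold higher number from compound 2 to compound 3 (0.55 log units; beyond the scatter), and places both saturated rings on the same side of compound 2.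

The compounds shown leave open whether a methyl group or a longer chain such as propyl on this nitrogen would give a lower number than ethyl does. They also do not say whether the methyl on the piperidine nitrogen matters, as a free secondary amine or a carboxylic acid on that ring would test.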